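The compounds below may be only part of what the source reports. "The series", "measured", "known", "first", "only" and "open" are said of these compounds alone.

Compound 2 `CSc1nc(N(C)C)c2ncn([C@@H]3C[C@@H](O)[C@H](CO)O3)c2n1` gives 188 uM in a functional assay on NALL-1 cells (Homo sapiens); on this read-out lower numbers stand for stronger inhibition and higher numbers for weaker inhibition. Among the measured compounds shown here, only one other number exists so far: compound 1 `CNc1nc(SC)nc2c1ncn2[C@@H]1C[C@@H](O)[C@H](CO)O1` gives 186 uM in this assay , and the two results lie within the scatter of each other, so neither can be called stronger or weaker. Compound 3 `CSc1nc(N)c2ncn([C@@H]3C[C@@H](O)[C@H](CO)O3)c2n1` differs from compound 2 by a single change: amino in place of dimethylamino on an aromatic carbon. Just one measured step bears on this change, the step of a 1.0-fold higher number from compound 1 to compound 2 (0.00 log units; within the scatter), in which a methyl replaced a hydrogen on the nitrogen of the same group and the number did not move beyond the scatter. The change to compound 3 goes the other way, trading the dimethylamino group for a plain amino group. For the measured compounds named here, since the only comparable step was flat, compound 3 is expected to give about 180 uM, somewhere between 60 uM and 540 uM, a step of a 1.0-fold lower number from compound 2 to compound 3 (0.02 log units; within the scatter) that is expected to stay within the scatter.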

Compound 3, concentration for 50% inhibition: 96 uM
Beside the measured number, compound 3's estimate is 1.9-fold (0.27 log units) above it, and the stated range covers the measured number.
By their numbers in this assay, from the lowest: compounds 3, 1 and 2 (each within the scatter of the next).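

Three groups on this aromatic carbon can now be compared in this assay: amino, dimethylamino and the single-methyl amine of compound 1. Replacing dimethylamino with amino gives a 2.0-fold lower number from compound 2 to compound 3 (0.29 log units; within the scatter), and removing the one methyl from the nitrogen gives a 1.9-fold lower number from compound 1 to compound 3 (0.29 log units; within the scatter). Both steps stay within the scatter, so neither the methyls on this nitrogen nor the hydrogen-bond donor that amino brings and dimethylamino lacks can be tied to a real difference in this read-out, and no outside data explain the numbers.

These three compounds leave open whether a larger group on the nitrogen, such as an ethyl or benzyl group, or a ring amine such as morpholine, would shift the number beyond the scatter. From the compounds shown here alone, they also keep the methylsulfanyl group fixed, so its role remains unknown.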